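Working notes: cytotoxicity of compounds 1 to 3

A few compounds are considered here, and "the series" means these few. Any claim that something is new, unique, unknown or untested is made for them only; others in the source may bear on it.

Measured so far:
compound 1, `Cc1nnc(SCC(=O)N/N=c2/scc(-c3ccccc3)n2-c2ccccc2)s1`: 197 ug/mL
compound 2, `O=C(CSc1nnnn1-c1ccccc1)N/N=c1/scc(-c2ccc(Br)cc2)n1-c1ccccc1`: 433 ug/mL

Both were run in an ADME assay on NIH3T3 cells (Mus musculus) for cytotoxicity, read by MTT assay, with a stated time of 24 h; a higher number here means a weaker inhibitor, a lower number a stronger inhibitor. Compound 1 gives 197 ug/mL and compound 2 gives 433 ug/mL; compound 2 holds the higher of the two numbers, and its gap to compound 1 lies beyond the usual scatter. The two differ in more than one place, so no single step can be read between them.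

Compound 3, `Cc1ccc(-c2cs/c(=N/NC(=O)CSc3nnnn3-c3ccccc3)n2-c2ccccc2)cc1`, is not yet measured in this assay. It differs from compound 2 as follows: methyl in place of bromo on an aromatic carbon. Among the compounds with values here, no comparable step exists among the measured compounds, so nothing anchors a direction for this change. The expectation for compound 3 is a step of a 1.1-fold lower number from compound 2 to compound 3 (0.03 log units; within the scatter) of no more than the usual scatter, in either direction. Compound 3 is therefore estimated at 400 ug/mL in this assay, with a range of 200 ug/mL to 800 ug/mL.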

Compound 3, half-maximal inhibitory concentration: > 500 ug/mL
Compound 3 ended at the assay's limit; the forecaster's own chance of this, stated with the estimate: 5%; middle value at least 1.2-fold (0.09 log units) from the limit.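

In this assay, compound 3 gives > 500 ug/mL, which is a limit of the assay and not a number. Within the data shown here, this is the only single-place step, 4-bromophenyl to 4-methylphenyl on an aromatic carbon para to a large group, and it reads as an at least 1.1-fold higher number from compound 2 to compound 3 (0.06 log units; that floor lies within the scatter). A lower number for the methyl compound is thus not seen, but only the floor of the step can be read, and that floor does not separate the two compounds, with the reading cut off at the top of the range: the limit of > 500 ug/mL in this assay, at which 1 of the 3 values shown sits.

Going by these compounds, how far compound 3 lies past its limit stays open, as does whether the same change would read alike in the setting of compound 1. On these data alone, what an amine or a carboxylic acid at this position would give in this assay also stays open.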